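The source may hold more compounds than are shown below. What is called first, only, known or untested is meant among the compounds shown, and "the series" means these compounds.

Measured in a functional assay on MKN-45 cells (Homo sapiens) for inhibition, read by MTT assay, with a stated time of 72 h; a lower number here means a stronger inhibitor, a higher number a weaker inhibitor:

Compound 1 `COc1cc2c(Oc3ccc(NC(=O)c4nn(-c5ccccc5C(F)(F)F)c(=O)cc4C)cc3F)ccnc2cc1OCCCN1CCC(C)CC1`: 60 nM
Compound 2 `COc1cc2c(Oc3ccc(NC(=O)c4nn(-c5ccccc5C(F)(F)F)c(=O)cc4C)cc3F)ccnc2cc1OCCCN1CCN(C)CC1`: 40 nM
Compound 3 `COc1cc2c(Oc3ccc(NC(=O)c4nn(-c5ccccc5OC(F)(F)F)c(=O)cc4C)cc3F)ccnc2cc1OCCCN1CCC(C)CC1`: 70 nM

Compound 4 `COc1cc2c(Oc3ccc(NC(=O)c4nn(-c5ccccc5OC(F)(F)F)c(=O)cc4C)cc3F)ccnc2cc1OCCCN1CCN(C)CC1` has not yet been measured in this assay. It differs from compound 3 by 4-methylpiperazin-1-yl in place of 4-methylpiperidin-1-yl on a saturated chain carbon, three bonds along the chain from an oxygen on an aromatic ring. The same change is already known from the pair compound 1 to compound 2, where it is 4-methylpiperazin-1-yl in place of 4-methylpiperidin-1-yl on a saturated chain carbon, three bonds along the chain from an oxygen on an aromatic ring and gave a 1.5-fold lower number from compound 1 to compound 2 (0.18 log units; within the scatter). The two cores on which this change is made differ by trifluoromethoxy in place of trifluoromethyl on an aromatic carbon, a difference that produced a 1.2-fold higher number from compound 1 to compound 3 (0.07 log units; within the scatter). Since the place of the change is described in the same words in both pairs, it is treated as the same change. For compound 4 the step from compound 3 is therefore expected to be a 1.6-fold lower number from compound 3 to compound 4 (0.19 log units; within the scatter), resting on compound 1 to compound 2 giving a 1.5-fold lower number from compound 1 to compound 2 (0.18 log units; within the scatter). Compound 4 is estimated at 45 nM, with a likely range from 20 nM to 100 nM.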

Compound 4, half-maximal inhibitory concentration: 100 nM
For compound 4 the middle estimate is 2.2-fold (0.35 log units) below the measured one; low and high end bracket the measured number.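

In this assay, 4-methylpiperazin-1-yl in place of 4-methylpiperidin-1-yl gives a 1.4-fold higher number from compound 3 to compound 4 (0.15 log units; within the scatter), and this step cannot be told apart from the one on the other core: the same change on two cores in this assay, a 1.5-fold lower number (0.18 log units; within the scatter) from compound 1 to compound 2 and a 1.4-fold higher number (0.15 log units; within the scatter) from compound 3 to compound 4, 2.1-fold (0.33 log units) apart, within the scatter of two such steps. Trifluoromethoxy in place of trifluoromethyl gives a 2.5-fold higher number from compound 2 to compound 4 (0.40 log units; beyond the scatter), a step that also cannot be separated from its counterpart: the same change on two cores in this assay, a 1.2-fold higher number (0.07 log units; within the scatter) from compound 1 to compound 3 and a 2.5-fold higher number (0.40 log units; beyond the scatter) from compound 2 to compound 4, 2.1-fold (0.33 log units) apart, within the scatter of two such steps. The change therefore carried from one core to the other without a readable gap, but two pairs show neither that it has no effect nor that it would carry to further cores.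

The compounds shown leave open whether morpholine in place of 4-methylpiperazin-1-yl would behave alike. They also leave open what a chlorine in place of trifluoromethyl would do.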